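Amine and chain variation at the aryl ether tail

This account rests on a few compounds, and the source may have more. Where it says the series, first, only, none or still open, it means among the compounds named here.

The series shares one core, varied only in the amine-bearing chain on the aromatic ether oxygen. Compound 1 `CN(C)CCCCCCCOc1ccc2oc(-c3ccccc3)cc(=O)c2c1` gives 165 nM in an assay on isolated protein (Cavia porcellus) with Sigma non-opioid intracellular receptor 1 (Homo sapiens) as the target, read by radioligand binding; a higher number here means a weaker inhibitor, a lower number a stronger inhibitor. Within the data shown here, compound 2 `CN(C)CCCCCCCCOc1ccc2oc(-c3ccccc3)cc(=O)c2c1` gives 227 nM in this assay, the highest of the three numbers so far. Compound 3 `O=c1cc(-c2ccccc2)oc2ccc(OCCCCCCN3CCCCC3)cc12` gives 101 nM in this assay. The steps read a 1.4-fold higher number from compound 1 to compound 2 (0.14 log units; within the scatter), a 1.6-fold lower number from compound 1 to compound 3 (0.21 log units; within the scatter) and a 2.2-fold lower number from compound 2 to compound 3 (0.35 log units; beyond the scatter).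

Compound 4 `CCN(CC)CCCCCCOc1ccc2oc(-c3ccccc3)cc(=O)c2c1` is not yet measured. Relative to compound 2 the change is diethylamino in place of 2-(dimethylamino)ethyl on a saturated chain carbon, six bonds along the chain from an oxygen on an aromatic ring. Among the measured compounds shown here, two measured steps bear on it: the shortening of the chain alone, from compound 1 to compound 2 in reverse, stayed within the scatter, while the step from compound 2 to compound 3, which also places a tertiary amine six bonds along the chain, gave a modest lowering beyond the scatter. Compound 4 lies between these cases, so a small lowering is expected, a 1.6-fold lower number from compound 2 to compound 4 (0.21 log units; within the scatter), probably at the edge of the scatter. Compound 4 is therefore estimated at 140 nM in this assay, within 70 nM to 280 nM.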

Compound 4, half-maximal inhibitory concentration: 91 nM
Compound 4: the middle estimate sits 1.5-fold (0.19 log units) above what was measured; measured number inside the range.
By their numbers in this assay, from the lowest: compounds 4, 3, 1 and 2 (each within the scatter of the next, the first and the last beyond it).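

In this assay, diethylamino in place of 2-(dimethylamino)ethyl at this place gives a 2.5-fold lower number from compound 2 to compound 4 (0.40 log units; beyond the scatter), so compound 2 now stands apart, beyond the scatter, from two compounds that carry their amine six bonds along the chain. The open diethylamino and the piperidin-1-yl ring cannot be told apart here, at a 1.1-fold lower number from compound 3 to compound 4 (0.05 log units; within the scatter), so closing the ring has no readable effect at this place. The step of a 1.8-fold lower number from compound 1 to compound 4 (0.26 log units; within the scatter) also stays within the scatter, so the diethylamino change is readable only against 2-(dimethylamino)ethyl.

Nothing at hand explains these numbers. Still open, on these data alone, are diethylamino on a longer chain, which would separate the amine from the chain length, and morpholine or pyrrolidine at this place.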